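From 4-hydroxyphenyl to 2-methylphenyl in compound 4

The source may hold more compounds than are shown below. What is called first, only, known or untested is meant among the compounds shown, and "the series" means these compounds.

In a functional assay on cells (Homo sapiens) for cytotoxicity, read by MTT assay, with a stated time of 24 h (a lower number here means a stronger inhibitor, a higher number a weaker inhibitor), compound 3 (`CCCCCCCCCCCCCCNC(=O)[C@H](CO)/N=C/c1ccc(O)cc1`) gives 19300 nM and compound 1 (`CCCCCCCCCCCCCCNC(=O)[C@H](CO)/N=C/c1ccccc1[N+](=O)[O-]`) gives 21700 nM in the same range (a 1.1-fold lower number from compound 1 to compound 3 (0.05 log units; within the scatter)). Compound 2 (`CCCCCCCCCCCCCCNC(=O)[C@H](CO)/N=C/c1cccc([N+](=O)[O-])c1`) gives 104000 nM and stands apart, through modest steps (a 4.8-fold higher number from compound 1 to compound 2 (0.68 log units; beyond the scatter)) and (a 5.4-fold lower number from compound 2 to compound 3 (0.73 log units; beyond the scatter)). Compound 4 (`CCCCCCCCCCCCCCNC(=O)[C@H](CO)/N=C/c1ccccc1C`) has 2-methylphenyl in place of 4-hydroxyphenyl on a carbon with a double bond to nitrogen. Among the measured compounds shown here, no compound with a methyl group has been measured, so these three alone guide the expectation. Since only compound 2 departs from the pair, a slightly higher number, within the scatter, is expected (a 1.6-fold higher number from compound 3 to compound 4 (0.19 log units; within the scatter)). For compound 4 the estimated value is 30000 nM with an expected range (12000 nM to 85000 nM).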

Compound 4, half-maximal inhibitory concentration: 87700 nM
Estimate against measurement, compound 4: 2.9-fold (0.47 log units) below, outside the stated range (above it).
By their numbers in this assay, from the lowest: compounds 3 and 1 (each within the scatter of the next); then compounds 4 and 2 (each within the scatter of the next).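

In this assay, methyl in place of nitro on an aromatic carbon is no neutral swap (a 4.0-fold higher number from compound 1 to compound 4 (0.61 log units; beyond the scatter)), so the 2-nitrophenyl result does not carry over to 2-methylphenyl. The step from 4-hydroxyphenyl is of similar size (a 4.5-fold higher number from compound 3 to compound 4 (0.66 log units; beyond the scatter)), whereas the step from 3-nitrophenyl stays small (a 1.2-fold lower number from compound 2 to compound 4 (0.07 log units; within the scatter)), so compound 2 no longer stands alone at this place. Nothing at hand accounts for these steps. As far as these compounds go, whether an amine or a carboxylic acid here would fall with compound 1 and compound 3, or with compound 2 and compound 4, remains open. So does the effect of a shorter chain on the shared core.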